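The source may report more compounds than this note shows. Statements on the series, on what has been measured and on what is new or still open speak of the compounds shown alone.

Measured compounds in a functional assay on HeLa cells (Homo sapiens) for inhibition, read by MTT assay, with a stated time of 72 h; a higher number here means a weaker inhibitor, a lower number a stronger inhibitor:

Compound 1 `NCC(=O)Nc1c[nH]c(=O)[nH]c1=O`: compound 1 gives > 100000 nM, which is a limit of the assay and not a number.
Compound 2 `O=c1ccn(COC(CO)CO)c(=O)[nH]1`: compound 2 gives > 100000 nM, again a limit of the assay.
Compound 3 `Nc1cn(COC(CO)CO)c(=O)[nH]c1=O`: compound 3 gives > 100000 nM, also a limit of the assay.

Among the compounds with values here, compound 3 therefore stands only at a limit in this assay, and so do its two companions: every value shown sits at the limit of > 100000 nM in this assay, at which 3 of the 3 values shown sit, so no compound can be set above or below another. Within the data shown here, the one measured step between close relatives, a step that the two limits leave unreadable from compound 2 to compound 3, gives no readable size, since both of its ends are limits.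

Compound 4 `O=c1[nH]c(=O)n(COC(CO)CO)cc1O` differs from compound 3 by hydroxy in place of amino on an aromatic carbon. Among the measured compounds shown here, no measured pair swaps an amino for a hydroxy at this position, and the single recorded step is unreadable, so the data offer nothing that points to a shift in this assay in either direction. With compound 3 and its relatives all resting at the limit, the expectation is simply that compound 4 behaves the same way. Compound 4 is estimated at 100000 nM, within a range of 30000 nM to 300000 nM, most likely reported again only as a limit. The step this estimate implies, a number no higher from compound 3 to compound 4 (the limit leaves the size open), is expected to be none beyond the scatter.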

Compound 4, half-maximal inhibitory concentration: > 100000 nM
Compound 4 was reported as a limit (the forecaster's own chance of this, stated with the estimate: 85%); the middle value sits exactly at the limit.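

In this assay compound 4 gives > 100000 nM, which is a limit of the assay and not a number. The steps from compound 2 and from compound 3 to compound 4 cannot be read, because all values rest at one limit: the limit of > 100000 nM in this assay, at which 4 of the 4 values shown sit.

The compounds shown leave open whether hydrogen, amino or hydroxy at this place on the shared core makes any difference in this assay.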